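The source may report more compounds than this note shows. Statements on the series, on what has been measured and on what is new or still open speak of the compounds shown alone.

Measured so far:
compound 1, `NC(=O)c1ncn(CCC2(O)NC(=O)C(OCc3ccccc3)=C2OCc2ccccc2)n1`: 445000 nM
compound 2, `COC(=O)c1ncn(CCC2(O)NC(=O)C(OCc3ccccc3)=C2OCc2ccccc2)c1C(=O)OC`: 35000 nM

Of the compounds shown here, two sharing the same core have been measured in a functional assay (CCRF-CEM cells, Homo sapiens), read by cell counting, with a stated time of 72 h; a higher number here means a weaker inhibitor, a lower number a stronger inhibitor. Compound 1 gives 445000 nM, the higher of the two numbers, and so the weaker inhibitor of the pair. Compound 2 gives 35000 nM in this assay, a difference that lies well beyond the usual scatter of repeated measurements.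

The next compound, compound 3, `NC(=O)c1ncn(CCC2(O)NC(=O)C(OCc3ccccc3)=C2OCc2ccccc2)c1C(N)=O`, has not yet been measured. It differs from compound 1 in a single place: 4,5-dicarbamoyl-1H-imidazol-1-yl in place of 3-carbamoyl-1H-1,2,4-triazol-1-yl on a saturated chain carbon, two bonds along the chain from a saturated ring carbon. No step between two measured compounds matches this change, so the expectation rests only on the two numbers shown. With compound 1 standing at the high end and compound 2 at 35000 nM, compound 3 is expected to give a lower number than compound 1, though without confidence that it reaches compound 2. The step from compound 1 to compound 3 is estimated at a 3.0-fold lower number from compound 1 to compound 3 (0.47 log units; beyond the scatter). For compound 3 in this assay the estimate is 150000 nM, with a plausible range from 40000 nM to 500000 nM.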

Compound 3, half-maximal inhibitory concentration: 154000 nM
Compound 3: the middle estimate sits 1.0-fold (0.01 log units) below what was measured; measured number inside the range.
By their numbers in this assay, from the lowest: compound 2; then compound 3; then compound 1.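

In this assay, exchanging the group carried on the chain gives a 2.9-fold lower number from compound 1 to compound 3 (0.46 log units; beyond the scatter). For the compounds shown here, this is the first step that can be read at this position, and it shows that changing the group carried on the chain moves the number beyond the usual scatter while the shared core stays the same. The step exchanges the ring and adds a second carbamoyl group at once, so it cannot show which of these differences accounts for the change, and nothing measured here offers an explanation for it.

The compounds shown leave open what an imidazol-1-yl group bearing only one carbamoyl group would give at this place, and whether a similar step would appear if carboxylic acid or nitrile groups took the place of the carbamoyl groups. They also leave open how the number would respond to a longer chain in place of the present one.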